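A few compounds are considered here, and "the series" means these few. Any claim that something is new, unique, unknown or untested is made for them only; others in the source may bear on it.

Of the compounds shown here, three that share a core have been measured in an assay on Sf9 cells for inhibition of protein deacetylase HDAC6 (Homo sapiens), read by fluorescence; on this read-out higher numbers stand for weaker inhibition and lower numbers for stronger inhibition. Compound 1 `O=C(NO)c1ccc(Cn2nnc(Cc3ccccn3)n2)cc1` gives 25 nM in this assay. Compound 2 `O=C(NO)c1ccc(Cn2nnc(-c3ccc(C(F)(F)F)cc3)n2)cc1` gives 11 nM in this assay, and compound 3 `O=C(O)c1cccc(-c2nnn(Cc3ccc(C(=O)NO)cc3)n2)c1` gives 12 nM in this assay. Among these three numbers compound 3 holds the second highest. The gap between compound 3 and compound 2 is within the scatter of this kind of measurement, so nothing separates them. Compound 1 has a higher number than compound 3, and that gap lies beyond the scatter.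

Compound 4 `O=C(NO)c1ccc(Cn2nnc(-c3ccccc3)n2)cc1` has not yet been measured. It differs from compound 3 in one place: hydrogen in place of carboxy on an aromatic carbon. Within the data shown here, both keep the shared core; only that one group is lost. Among the measured compounds shown here, no step between two measured compounds shows exactly this change, so the expectation rests on how little the three known numbers spread even though their outer groups differ. The step from compound 3 to compound 4 is expected to be small, in either direction, and likely not beyond the scatter: a 1.3-fold higher number from compound 3 to compound 4 (0.10 log units; within the scatter). Compound 4 is therefore expected to give about 15 nM in this assay, with a range from 6 nM to 40 nM.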

Compound 4, half-maximal inhibitory concentration: 3 nM
Compound 4: middle estimate off by 5.0-fold (0.70 log units), on the high side; the whole stated range lies above it.
By their numbers in this assay, from the lowest: compound 4; then compounds 2 and 3 (each within the scatter of the next); then compound 1.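

Hydrogen in place of carboxy gives a 4.0-fold lower number from compound 3 to compound 4 (0.60 log units; beyond the scatter) in this assay and so shows that the carboxy group, meta to a large group, is not needed for inhibition here; the unsubstituted ring does better than the ring that carries it. Hydrogen in place of trifluoromethyl gives a 3.7-fold lower number from compound 2 to compound 4 (0.56 log units; beyond the scatter) and points the same way, something the earlier compounds could not show, since compound 2 and compound 3 sit within the scatter of each other and neither had a partner without its added group. Phenyl in place of (pyridin-2-yl)methyl gives an 8.3-fold lower number from compound 1 to compound 4 (0.92 log units; beyond the scatter) and extends the comparison, with no compound here going against the finding that the plain phenyl compound has the lowest number.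

Nothing measured here explains why these added groups go with weaker inhibition. From the compounds shown here alone, it also remains open whether any group on that ring can match hydrogen, for example a methyl group, a fluorine atom or an amine on the same carbon that carries carboxy in compound 3.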